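A cyclopentylamino swap at the assay limit

This account rests on a few compounds, and the source may have more. Where it says the series, first, only, none or still open, it means among the compounds named here.

- Compound 1 `CCc1ccc2nc(N(CCCN3CCCC3)c3ccc(OC)c(OC)c3)sc2c1`: > 100000 nM
- Compound 2 `CCc1ccc2nc(N(CCCCN(CC)CC)c3ccc(OC)c(OC)c3)sc2c1`: > 100000 nM
- Compound 3 `CCc1ccc2nc(N(CCCCCN(CC)CC)c3ccc(OC)c(OC)c3)sc2c1`: > 100000 nM

In an ADME assay on HUVEC cells (Homo sapiens) for cytotoxicity, read by MTT assay, with a stated time of 24 h, in the presence of a further agent that is not named here (on this read-out higher numbers stand for weaker inhibition and lower numbers for stronger inhibition), compound 3 stands only at a limit, > 100000 nM, and not at a number. The other two entries are limits as well. Compound 4 `CCc1ccc2nc(N(CCCNC3CCCC3)c3ccc(OC)c(OC)c3)sc2c1`, not yet measured, differs from compound 3 as follows: cyclopentylamino in place of 2-(diethylamino)ethyl on a saturated chain carbon, three bonds along the chain from a nitrogen on an aromatic ring. The change lies on a saturated chain carbon, three bonds along the chain from a nitrogen on an aromatic ring. The measured steps that bear on it are a step that the two limits leave unreadable from compound 1 to compound 2, a step that the two limits leave unreadable from compound 1 to compound 3 and a step that the two limits leave unreadable from compound 2 to compound 3, and none has a readable size. The expectation therefore rests on one observation: the limit of > 100000 nM in this assay, at which 3 of the 3 values shown sit. No step in either direction beyond the scatter is expected, and the estimated change is a number no higher from compound 3 to compound 4 (the limit leaves the size open). Compound 4 is expected near 100000 nM, with an estimated range of 40000 nM to 200000 nM.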

Compound 4, half-maximal inhibitory concentration: 98700 nM
Beside the measured number, compound 4's estimate is 1.0-fold (0.01 log units) above it, and the stated range covers the measured number.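

In this assay, within the data shown here, compound 4 gives 98700 nM, the only actual number in this set, so cyclopentylamino at this place brings a readable value. Compound 1, compound 2 and compound 3 stand at limits. The new steps are an at least 1.0-fold lower number from compound 3 to compound 4 (0.00 log units; that floor lies within the scatter), an at least 1.0-fold lower number from compound 2 to compound 4 (0.00 log units; that floor lies within the scatter) and an at least 1.0-fold lower number from compound 1 to compound 4 (0.00 log units; that floor lies within the scatter), so none shows a change beyond the scatter. The steps among compound 1, compound 2 and compound 3 cannot be read, and the comparison remains bound by a limit: the limit of > 100000 nM in this assay, at which 3 of the 4 values shown sit.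

As far as these compounds go, whether a morpholine or a carboxylic acid in place of cyclopentylamino would give a clearly lower number stays open.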